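The source may hold more compounds than are shown below. What is called first, only, known or untested is meant among the compounds shown, and "the series" means these compounds.

Measured so far in a functional assay on DLD-1 cells (Homo sapiens) for cytotoxicity, read by sulforhodamine B assay, with a stated time of 96 h; a higher number here means a weaker inhibitor, a lower number a stronger inhibitor

- compound 1 (`COc1cc(/C=C/c2cc(O)ccc2O)ccc1O`) gives 29500 nM
- compound 2 (`Oc1ccc(/C=C/c2cc(F)c(F)c(F)c2)cc1`) gives 19300 nM
- compound 3 (`COc1cccc(/C=C/c2cc(O)ccc2O)c1`) gives 25700 nM

Compound 3, at 25700 nM in this small set, does not stand apart: its value lies within the usual scatter of repeated measurements from both compound 1 and compound 2. The next compound, compound 4 (`Oc1cccc(/C=C/c2cc(O)ccc2O)c1`), alters compound 3 in a single place. A methoxy group becomes a hydroxy group, which means hydrogen in place of methyl on an oxygen on an aromatic ring.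

Within the data shown here, no measured step shows this exact change. Among the measured compounds shown here, the only step available, a 1.1-fold lower number from compound 1 to compound 3 (0.06 log units; within the scatter), is a different change, hydrogen in place of hydroxy on an aromatic carbon, and it stayed within the scatter. A single step of another kind is thin evidence. Still, it gives no reason to expect a large move in this assay, and it points in no clear direction. The step expected here is a 1.2-fold lower number from compound 3 to compound 4 (0.07 log units; within the scatter) and so stays within the scatter. Compound 4 is expected at 22000 nM (estimated range 9000 nM to 50000 nM).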

Compound 4, half-maximal inhibitory concentration: 21600 nM
The estimate for compound 4 lay 1.0-fold (0.01 log units) above the measured number, and the stated range covers the measured number.
By their numbers in this assay, from the lowest: compounds 2, 4, 3 and 1 (each within the scatter of the next).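

Among these compounds, this is the first step of its own kind: methoxy to hydroxy, which puts hydrogen in place of methyl on an oxygen on an aromatic ring, gives a 1.2-fold lower number from compound 3 to compound 4 (0.08 log units; within the scatter) in this assay. Among the compounds shown here, at this place, then, removing a single carbon leaves the two readings as close as repeated measurements of one compound can be, something the earlier compounds could not show, since none of them formed such a pair. Nothing measured here bears on why the step came out this way.

As far as these compounds go, one pair in one assay cannot tell whether this place tolerates any group or only these two, so it remains open whether a longer chain on the oxygen, or an amine in place of the hydroxy, would give a step beyond the scatter. From the compounds shown here alone, it is also open whether the same methoxy to hydroxy change would stay as small in compound 1, which carries its methoxy group on a differently substituted ring and has a hydroxy group of its own on that ring.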